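Methyl on the Ring Nitrogen and Chk2 Inhibition

The source may hold more compounds than are shown below. What is called first, only, known or untested is meant among the compounds shown, and "the series" means these compounds.

Measured compounds:
compound 1, `Cc1cc2[nH]nc(N)c2c(=O)[nH]1`: 27%
compound 2, `Cc1cc2[nH]nc(N)c2c(N2CCCCC2)n1`: 33%
compound 3, `Cc1cc2c(c(N)nn2C)c(=O)[nH]1`: 3%

In an assay on isolated protein for inhibition of serine/threonine-protein kinase Chk2 (Homo sapiens), read by mobility shift assay, tested at 30 uM (on this read-out lower numbers stand for less inhibition and higher numbers for more inhibition at the one concentration tested (going by the name of the read-out)), compound 1 gives 27%, while compound 2 gives 33%, a number within the scatter of compound 1. Compound 3 gives 3%. Compound 3 is made from compound 1 by a single change, (methyl in place of hydrogen on an aromatic nitrogen), and the step from compound 1 to compound 3 is a number 24 percentage points lower from compound 1 to compound 3 (beyond the scatter). Compound 2 and compound 1 differ in more than one place; the difference between the two cores is not broken down here.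

Compound 4, `Cc1cc2c(c(N)nn2C)c(N2CCCCC2)n1`, has not yet been measured. It is made from compound 2 by methyl in place of hydrogen on an aromatic nitrogen, the same change that turns compound 1 into compound 3, and this change appears in both pairs and nowhere else among the compounds shown.

The expectation for compound 4 rests on compound 2, because 33% is the starting point, and on the step from compound 1 to compound 3, because a number 24 percentage points lower from compound 1 to compound 3 (beyond the scatter) shows what this change did once before. Compound 4 is thus expected to show a step of a number 24 percentage points lower from compound 2 to compound 4 (beyond the scatter), close in size to the earlier one. On this basis compound 4 is estimated at 9%, with a likely range from 0% to 22%.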

Compound 4, a percentage reported as inhibition, at one concentration (the size of the read-out at that concentration, not a potency): 4%
Compound 4: middle estimate off by 5 percentage points, on the high side; the range from low to high includes it.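

In this assay, methyl in place of hydrogen on an aromatic nitrogen gives a number 29 percentage points lower from compound 2 to compound 4 (beyond the scatter), and this step matches the one seen earlier on the other core: the same change on two cores in this assay, a number 24 percentage points lower (beyond the scatter) from compound 1 to compound 3 and a number 29 percentage points lower (beyond the scatter) from compound 2 to compound 4, 5 percentage points apart, within the scatter of two such steps Within these two pairs the change therefore carries over from one core to the other, and both methylated compounds end up with little inhibition left, with compound 3 at 3% and compound 4 at 4%. Among these compounds, this rests on only two pairs, each read at a single concentration, so it does not show that the step would hold on any further core, and it gives no potency and no reason for the loss.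

The compounds shown leave open whether the loss is particular to methyl or would also follow from ethyl, a longer chain or a carboxylic acid-bearing chain on that ring nitrogen. They also leave open how the amino group on the ring contributes, since it stays the same throughout, and whether an acylated amine or another group in its place would alter the size of the step.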